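Replacing the group at the chain end of compound 1

A few compounds are considered here, and "the series" means these few. Any claim that something is new, unique, unknown or untested is made for them only; others in the source may bear on it.

In a functional assay on HeLa cells (Homo sapiens) for antiproliferative activity, read by MTT assay, with a stated time of 72 h (a higher number here means a weaker inhibitor, a lower number a stronger inhibitor), compound 1 `O=C1NC(O)(CCn2cnc3cc[nH]c3c2=O)C(OCc2ccccc2)=C1OCc1ccccc1` gives 92000 nM, the higher of the two actual numbers. Compound 2 `O=C1O/C(=C\Cn2cnc3cc[nH]c3c2=O)C(OCc2ccccc2)=C1OCc1ccccc1` gives 27000 nM, a lower number by more than the usual scatter. Compound 3 `O=C1NC(O)(/C=C\n2cc(I)c3c(Cl)ncnc32)C(OCc2ccccc2)=C1OCc1ccccc1` gave only a limit, > 250000 nM. Compound 4 `O=C1NC(O)(CCn2cnc3ccnc(Cl)c32)C(OCc2ccccc2)=C1OCc1ccccc1` keeps the core of compound 1 but exchanges the group on the saturated chain carbon: a group of 10 heavy atoms (6 carbon, 3 nitrogen, 1 chlorine; one five-membered aromatic ring with 2 hetero atoms, one six-membered aromatic ring with 1 hetero atom) in place of a group of 10 heavy atoms (6 carbon, 3 nitrogen, 1 oxygen; one five-membered aromatic ring with 1 hetero atom, one six-membered aromatic ring with 2 hetero atoms), on a saturated chain carbon, two bonds along the chain from a saturated ring carbon. Among the compounds with values here, no measured pair shows this exchange, so any forecast is loose. Compound 2 at 27000 nM shows that a lower number is within reach, so a modest shift towards stronger inhibition is expected. The expected step is a 3.7-fold lower number from compound 1 to compound 4 (0.57 log units; beyond the scatter). For compound 4 the estimated value is 25000 nM, with an expected range of 4000 nM to 150000 nM.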

Compound 4, half-maximal inhibitory concentration: 21000 nM
Beside the measured number, compound 4's estimate is 1.2-fold (0.08 log units) above it; the measured number falls inside the stated range.
By their numbers in this assay, from the lowest: compounds 4 and 2 (each within the scatter of the next); then compound 1. At a limit, above all of these: compound 3.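

Within the data shown here, compound 1 and compound 4 are the only pair here that differ in one place, so they give the one direct reading of the group on the saturated chain carbon. With the shared core held fixed, the exchange of groups gives a 4.4-fold lower number from compound 1 to compound 4 (0.64 log units; beyond the scatter) in this assay and shows that this position affects the read-out. No measurement shown explains why.

As far as these compounds go, the two groups differ in their ring nitrogens, their hydrogen-bond donors and the chlorine all at once, so which difference matters stays open. From the compounds shown here alone, how an amine in place of the chlorine, or a longer chain, would read also remains open.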